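Permeability notes: bromo in place of ring hydrogen

This account rests on a few compounds, and the source may have more. Where it says the series, first, only, none or still open, it means among the compounds named here.

Measured compounds in this series:
compound 1 `O=C(Cc1c[nH]c2ccccc12)NCCC1CCN(Cc2ccccc2)CC1`: 2.4 10^-6 cm/s
compound 2 `Cn1cc(CC(=O)NCCC2CCN(Cc3ccccc3)CC2)c2ccccc21`: 7.3 10^-6 cm/s
compound 3 `Cn1cc(C(=O)NCCC2CCN(Cc3ccccc3)CC2)c2ccccc21`: 4.8 10^-6 cm/s

In an ADME assay for permeability, using PAMPA, with a stated time of 2.5 h (on this read-out higher numbers stand for higher permeability and lower numbers for lower permeability), compound 1 gives 2.4 10^-6 cm/s, the smallest number of the three, but its gap to compound 3 at 4.8 10^-6 cm/s is within the scatter, so those two cannot be separated; compound 2 at 7.3 10^-6 cm/s stands beyond the scatter above compound 1. Among the compounds with values here, the only single-change step measured is a 3.0-fold higher number from compound 1 to compound 2 (0.48 log units; beyond the scatter), methyl in place of hydrogen on an aromatic nitrogen.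

Compound 4 `O=C(Cc1c[nH]c2ccc(Br)cc12)NCCC1CCN(Cc2ccccc2)CC1` differs from compound 1 by bromo in place of hydrogen on an aromatic carbon. Within the data shown here, no measured step in the set touches an aromatic carbon of the shared core, so the bromo change has no direct precedent here; the methyl step on the nitrogen is a different place and a different group and bears on it only loosely. The number for compound 4 is therefore expected to stay close to that of compound 1, a step of a 1.5-fold higher number from compound 1 to compound 4 (0.16 log units; within the scatter) with a wide band of uncertainty. The estimate for compound 4 in this assay is 3.5 10^-6 cm/s, in the range 1.2 10^-6 cm/s to 10 10^-6 cm/s.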

Compound 4, apparent permeability: 5.8 10^-6 cm/s
Beside the measured number, compound 4's estimate is 1.7-fold (0.22 log units) below it; low and high end bracket the measured number.
By their numbers in this assay, from the lowest: compounds 1, 3, 4 and 2 (each within the scatter of the next, the first and the last beyond it).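

In this assay the aromatic carbon of the six-membered aromatic ring of carbon only responds to substitution: bromo in place of hydrogen gives a 2.4-fold higher number from compound 1 to compound 4 (0.38 log units; beyond the scatter) and so moves the number beyond the scatter. Within the data shown here, until now the only such step on compound 1 was at the aromatic nitrogen, a 3.0-fold higher number from compound 1 to compound 2 (0.48 log units; beyond the scatter) and this result shows that a change at a second place, with a different group, also raises the number, with compound 2 and compound 4 both lying on that side of compound 1. Nothing available explains the step made by bromo.

From the compounds shown here alone, whether a chloro, a methoxy, an amine or a carboxylic acid on the same carbon would move the number in the same direction remains open. So does the outcome of bromo and the methyl on the aromatic nitrogen together in one compound.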